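From Iodo to Cyano: Estimating Compound 4

This account rests on a few compounds, and the source may have more. Where it says the series, first, only, none or still open, it means among the compounds named here.

Of the compounds shown here, three sharing one core have been measured in an assay on isolated protein for inhibition of Amine oxidase [flavin-containing] A (Homo sapiens), read by fluorescence and spectrophotometry, with a stated time of 30 min; a lower number here means a stronger inhibitor, a higher number a weaker inhibitor. Compound 1 `O=C1CCCc2cc(OCc3cccc(Cl)c3)ccc21` gives 207 nM, compound 2 `O=C1CCCc2cc(OCc3ccc(Br)cc3)ccc21` gives 311 nM, and compound 3 `O=C1CCCc2cc(OCc3cccc(I)c3)ccc21` gives 1290 nM, the highest number of the three, so compound 3 is the weakest inhibitor among them. For the measured compounds named here, the only measured step that touches compound 3 is a 6.2-fold higher number from compound 1 to compound 3 (0.79 log units; beyond the scatter), modest but beyond the scatter. Compound 4 `N#Cc1cccc(COc2ccc3c(c2)CCCC3=O)c1` differs from compound 3 by cyano in place of iodo on an aromatic carbon. Going by the values given here, no measured compound carries a cyano, so that single step is the only guide, and it shows that changing the group at this position can shift this assay by a modest amount. Compound 4 is therefore estimated at 400 nM, within 100 nM to 1600 nM, which would mean an expected 3.2-fold lower number from compound 3 to compound 4 (0.51 log units; beyond the scatter).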

Compound 4, half-maximal inhibitory concentration: 24 nM
Compound 4: the middle estimate sits 17-fold (1.22 log units) above what was measured, outside the stated range (below it).
By their numbers in this assay, from the lowest: compound 4; then compounds 1 and 2 (each within the scatter of the next); then compound 3.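

Swapping iodo for cyano on this aromatic carbon gives a 54-fold lower number from compound 3 to compound 4 (1.73 log units; beyond the scatter), so in this assay the group here can matter far more than the earlier halogen step suggested. Cyano in place of chloro gives an 8.6-fold lower number from compound 1 to compound 4 (0.94 log units; beyond the scatter), so the change also outdoes the better of the two halogens compared at this place. Nothing available explains this gain. Still open, from the compounds shown here alone, is whether another group here, such as an amine, a carboxylic acid or a methoxy group, would match cyano or go further.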